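The source may report more compounds than this note shows. Statements on the series, on what has been measured and on what is new or still open speak of the compounds shown alone.

For the measured compounds named here, compound 2 `Nc1cccc2c(-c3cccc(NC(=O)Nc4cc(C(F)(F)F)cc(C(F)(F)F)c4)c3)ccnc12` is the only compound here that gives a plain number in a functional assay on A375P cells (Homo sapiens) for antiproliferative activity, read by MTT assay, with a stated time of 48 h; on this read-out lower numbers stand for stronger inhibition and higher numbers for weaker inhibition: compound 2 gives 1400 nM. Compound 1 `CC(=O)Nc1cccc2c(-c3cccc(NC(=O)c4cc(C)oc4C)c3)ccnc12` stands at a limit of the assay rather than at a number: in this assay compound 1 gives > 20000 nM, which is the limit of > 20000 nM in this assay, at which 1 of the 2 values shown sits. Compound 3 `CC(=O)Nc1cccc2c(-c3cccc(NC(=O)Nc4cc(C(F)(F)F)cc(C(F)(F)F)c4)c3)ccnc12` differs from compound 2 by acetyl in place of hydrogen on a nitrogen on an aromatic ring. Going by the values given here, no measured pair shows this exact change, so only a modest loss is expected, about a 2.1-fold higher number from compound 2 to compound 3 (0.33 log units; beyond the scatter) in this assay. Compound 3 is therefore estimated to give 3000 nM in this assay, within 800 nM to 12000 nM.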

Compound 3, half-maximal inhibitory concentration: 4400 nM
Compound 3: the middle estimate sits 1.5-fold (0.17 log units) below what was measured, and the stated range covers the measured number.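

Going from amino to acetamido gives a 3.1-fold higher number from compound 2 to compound 3 (0.50 log units; beyond the scatter) in this assay, so on this nitrogen acetyl in place of hydrogen costs only a modest loss, and compound 3 still gives a plain number. For the compounds shown here, the earlier compounds held no pair with this change, and this single step is the first reading of it. Nothing measured here gives a reason for the loss.

The compounds shown leave open how a longer acyl chain such as propionyl, or a single methyl on this nitrogen, would read. As far as these compounds go, whether the same step holds on other compounds also stays open.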